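The source may report more compounds than this note shows. Statements on the series, on what has been measured and on what is new or still open speak of the compounds shown alone.

Going by the values given here, compound 1 `Cc1cc(Nc2cc(-c3cccs3)[nH]n2)n2nc(SCc3ccc(Br)cc3)nc2n1` is the only compound here with a definite number: in a functional assay on PC-9 cells (Homo sapiens) for inhibition, read by MTT assay, with a stated time of 72 h (on this read-out lower numbers stand for stronger inhibition and higher numbers for weaker inhibition), compound 1 gives 4890 nM. Compound 2 `Cc1nc2nc(SCc3ccc(Cl)cc3)nn2c(Nc2cc(-c3ccccc3)[nH]n2)c1C` stands apart, since in this assay compound 2 reaches only a limit of the assay, > 50000 nM, which is the limit of > 50000 nM in this assay, at which 1 of the 2 values shown sits. Compound 3 `Cc1cc(Nc2cc(C(C)(C)C)[nH]n2)n2nc(SCc3ccc(Br)cc3)nc2n1` alters compound 1 at a single point (tert-butyl in place of thiophen-2-yl on an aromatic carbon). Among the compounds with values here, no step between two measured compounds is available to gauge such a change, so in this assay a weakening step of modest size is expected, a 1.8-fold higher number from compound 1 to compound 3 (0.26 log units; within the scatter). For compound 3 the expected value in this assay is 9000 nM, within a range from 2500 nM to 35000 nM.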

Compound 3, half-maximal inhibitory concentration: 12400 nM
Compound 3: the middle estimate sits 1.4-fold (0.14 log units) below what was measured, within the range that was stated.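

Going by these compounds alone, this is the first measured step at this aromatic carbon: in this assay, tert-butyl in place of thiophen-2-yl gives a 2.5-fold higher number from compound 1 to compound 3 (0.40 log units; beyond the scatter). The position therefore responds to the group it carries, yet compound 3, with no ring on this carbon, still gives a definite number rather than a limit. Nothing measured here explains the rise.

Going by these compounds, how a methyl, an amine or a carboxylic acid on this carbon would read remains open. So does whether a six-membered ring such as pyridine would behave like thiophen-2-yl or like tert-butyl.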